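Adding a fluoro to compound 1 and the expected exposure

The source may hold more compounds than are shown below. What is called first, only, known or untested is meant among the compounds shown, and "the series" means these compounds.

For the measured compounds named here, compound 1 `CC(C)CC1(O)CCN(C(=O)Nc2cc(Oc3ccc(F)cc3)cc(Oc3ccc(C(=O)O)cc3)c2)CC1` gives 70 ng.h/mL in an ADME assay on the whole organism for pharmacokinetics, with Rattus norvegicus as the target, with a stated time of 24 h, at a dose of 1 mg/kg by the oral route (on this read-out higher numbers stand for higher exposure at the dose given and lower numbers for lower exposure), the lower of the two numbers measured so far. Compound 2 `CC(C)CC1(O)CCN(C(=O)Nc2cc(Oc3ccc(F)cc3)cc(Oc3ccc(C(C)(C)C(=O)O)cc3)c2)CC1` gives 390 ng.h/mL, and the step of a 5.6-fold higher number from compound 1 to compound 2 (0.75 log units; beyond the scatter) shows a modest gain. Compound 3 `CC(C)CC1(O)CCN(C(=O)Nc2cc(Oc3ccc(C(=O)O)cc3)cc(Oc3ccc(F)c(F)c3)c2)CC1` differs from compound 1 in one place: fluoro in place of hydrogen on an aromatic carbon. No measured step covers an added fluoro; the only step shown concerns the acid side of the molecule and is unrelated. Compound 3 is therefore expected to sit near compound 1, with a step of a 1.1-fold higher number from compound 1 to compound 3 (0.03 log units; within the scatter), not beyond the scatter, giving an estimate of 75 ng.h/mL within 25 ng.h/mL to 220 ng.h/mL.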

Compound 3, area under the concentration-time curve: 62 ng.h/mL
Estimate against measurement, compound 3: 1.2-fold (0.08 log units) above; the measured number falls inside the stated range.
By their numbers in this assay, from the lowest: compounds 3 and 1 (each within the scatter of the next); then compound 2.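

In this assay, the change from 4-fluorophenyl to 3,4-difluorophenyl gives a 1.1-fold lower number from compound 1 to compound 3 (0.05 log units; within the scatter). This shows that a fluoro can enter this position, on an aromatic carbon ortho to a fluoro group, with no step beyond the scatter, whereas the earlier step concerned only the carboxy side. Nothing available bears on why the read-out responds in this way. Still open, as far as these compounds go, is whether a chloro, a methoxy or an amine at this position would behave alike. Also open, from the compounds shown here alone, is whether the fluoro would read the same alongside the 1-carboxy-1-methylethyl group of compound 2.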